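From acetoxy to amino on a double-bonded nitrogen

This account rests on a few compounds, and the source may have more. Where it says the series, first, only, none or still open, it means among the compounds named here.

- Compound 1 `CCn1ccc2cc(/C(=N\OC(C)=O)c3cc(OC)c(OC)c(OC)c3)ccc21`: > 1000 nM (a limit)
- Compound 2 `CCn1ccc2cc(/C(=N/OC(C)=O)c3cc(OC)c(OC)c(OC)c3)ccc21`: > 1000 nM (a limit)

In a functional assay on HL-60 cells (Homo sapiens) for cytotoxicity, read by XTT assay, with a stated time of 72 h (on this read-out higher numbers stand for weaker inhibition and lower numbers for stronger inhibition), compound 1 gives > 1000 nM, which is a limit and not a number. Compound 3 `CCn1ccc2cc(/C(=N\N)c3cc(OC)c(OC)c(OC)c3)ccc21` carries amino in place of acetoxy on a double-bonded nitrogen. For the measured compounds named here, the only measured step is a step that the two limits leave unreadable from compound 1 to compound 2. It rests on the limit of > 1000 nM in this assay, at which 2 of the 2 values shown sit, and on (the fact that compounds 1 and 2 differ only in the configuration as drawn), so it gives no size for a swap of groups on this nitrogen. Going by the values given here, the expectation therefore has no measured step behind it and starts only from the limit of compound 1 at > 1000 nM. A loose lean towards stronger inhibition is expected, with the estimated step being an at least 2.5-fold lower number from compound 1 to compound 3 (0.39 log units; beyond the scatter). For compound 3 the estimate is 400 nM, with an expected range from 40 nM to 2000 nM.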

Compound 3, half-maximal inhibitory concentration: > 1000 nM
Compound 3 ended at the assay's limit; the forecaster's own chance of this, stated with the estimate: 45%; middle value at least 2.5-fold (0.39 log units) away from the limit.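

No step can be read between compound 1 and compound 3, since each value is a limit and not a number: the limit of > 1000 nM in this assay, at which 3 of the 3 values shown sit.

The compounds shown leave open whether amino in place of acetoxy on a double-bonded nitrogen changes inhibition at all, and by how much.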